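This account rests on a few compounds, and the source may have more. Where it says the series, first, only, none or still open, it means among the compounds named here.

Measured in an ADME assay on HEK-293T cells (Homo sapiens) for cytotoxicity, read by luminescence, with a stated time of 24 h; a higher number here means that more compound is tolerated, a lower number that less compound is tolerated:
Compound 1 `COc1ccc(Cn2c(C(=O)N3CCC(C(=O)NC(C)c4ccccc4)CC3)cc3sccc32)cc1`: > 100000 nM, a limit of the assay.
Compound 2 `CCCCC(=O)C1CCN(C(=O)c2cc3sccc3n2Cc2ccc(OC)cc2)CC1`: 38900 nM.

Going by the values given here, compound 2, at 38900 nM, holds the only actual number so far in this assay. Compound 1 stands at the limit of > 100000 nM in this assay, at which 1 of the 2 values shown sits.

Compound 3 `COc1ccc(Cn2c(C(=O)N3CCC(C(=O)NC4CC4)CC3)cc3sccc32)cc1` differs from compound 2 by one change: cyclopropylamino in place of butyl on a carbonyl carbon. Among the compounds with values here, one measured step bears on this, an at least 2.5-fold lower number from compound 1 to compound 2 (0.41 log units; beyond the scatter), which put butyl in place of (1-phenylethyl)amino on that same carbonyl carbon. The new change again puts an amino group there, though a smaller one, so the measured step is expected to reverse at least in part. A higher number of similar size is therefore expected, and another limit reading is quite possible. That is an expected 2.2-fold higher number from compound 2 to compound 3 (0.34 log units; beyond the scatter). For compound 3 the estimated value is 85000 nM, with an expected range of 35000 nM to 200000 nM.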

Compound 3, half-maximal cytotoxic concentration: 21400 nM
For compound 3 the middle estimate is 4.0-fold (0.60 log units) above the measured one, and the stated range ends above it.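

In this assay, cyclopropylamino in place of butyl on the carbonyl carbon gives a 1.8-fold lower number from compound 2 to compound 3 (0.26 log units; within the scatter), so an amino group at this position does not by itself separate compound 3 from compound 2. With the amino link kept, cyclopropyl in place of 1-phenylethyl on the amide-type nitrogen gives an at least 4.6-fold lower number from compound 1 to compound 3 (0.66 log units; beyond the scatter), which shows that, among these three compounds, the group on that nitrogen matters more than the presence of the nitrogen itself. The size of that step remains a bound, as the value of compound 1 is a limit of the assay and not a number: the limit of > 100000 nM in this assay, at which 1 of the 3 values shown sits.

Going by these compounds, it remains open whether a benzyl or an isopropyl group on that nitrogen would give a number closer to that of compound 1. Also open, on these data alone, is what a carboxylic acid at the same carbonyl carbon would give.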